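Swapping Fluoro for Methyl: Expected Cytotoxicity of Compound 4

The source may hold more compounds than are shown below. What is called first, only, known or untested is meant among the compounds shown, and "the series" means these compounds.

Three compounds have been measured in an ADME assay on RD cells (Homo sapiens) for cytotoxicity, read by MTT assay, with a stated time of 3 days; on this read-out higher numbers stand for lower toxicity in this test and lower numbers for higher toxicity in this test:
compound 1 `CC[C@@H](CCn1cncn1)c1ccc(F)cc1` gives 91.6 ug/mL
compound 2 `CC[C@@H](CCn1cncn1)c1ccc(C)cc1` gives 79.4 ug/mL
compound 3 `CCC[C@H](CCn1cncn1)c1ccc(F)cc1` gives 38.4 ug/mL

Compound 2 differs from compound 1 by methyl in place of fluoro on an aromatic carbon; the step is a 1.2-fold lower number from compound 1 to compound 2 (0.06 log units; within the scatter). Compound 3 has the lowest number of the three; how its core differs from the core of compound 1 is not broken down here. Compound 4 `CCC[C@H](CCn1cncn1)c1ccc(C)cc1`, not yet measured, differs from compound 3 by methyl in place of fluoro on an aromatic carbon, the same change as that between compound 1 and compound 2. Because the earlier step of a 1.2-fold lower number from compound 1 to compound 2 (0.06 log units; within the scatter) stayed within the scatter, a similar small step is expected here, a 1.2-fold lower number from compound 3 to compound 4 (0.07 log units; within the scatter). Compound 4 is therefore expected to give about 33 ug/mL in this assay, from 18 ug/mL to 62 ug/mL.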

Compound 4, half-maximal cytotoxic concentration: 47.2 ug/mL
Estimate against measurement, compound 4: 1.4-fold (0.16 log units) below; low and high end bracket the measured number.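

In this assay, methyl in place of fluoro gives a 1.2-fold higher number from compound 3 to compound 4 (0.09 log units; within the scatter), so on this second core the change again moves the number no further than repeated measurements would. The two steps agree, and in this small set the change carries from one core to the other as one that makes no clear difference: the same change on two cores in this assay, a 1.2-fold lower number (0.06 log units; within the scatter) from compound 1 to compound 2 and a 1.2-fold higher number (0.09 log units; within the scatter) from compound 3 to compound 4, 1.4-fold (0.15 log units) apart, within the scatter of two such steps. This does not show that the change has no effect at all, as a small real effect could hide within the scatter, and two cores cannot speak for other cores in the series.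

The compounds shown carry only fluoro or methyl at this place on the aromatic ring. Going by these compounds, it remains open whether an amine, a carboxylic acid or a longer chain there would shift the number beyond the scatter.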